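The compounds below may be only part of what the source reports. "The series", "measured", "known", "first", "only" and "open" are said of these compounds alone.

Working notes on a small series of positive allosteric modulators of the rat metabotropic glutamate receptor 2, all sharing the core of compound 1 `Cc1c(OCCCCOCOc2ccc(C(=O)O)cc2)ccc(C(=O)CC2CCCC2)c1O` and differing only in the aryl group carried on an oxygen on a saturated carbon. In an assay on HEK293 cells for positive allosteric modulation of metabotropic glutamate receptor 2 (Rattus norvegicus), read by thallium flux, with a stated time of 2.5 min (on this read-out higher numbers stand for an effect only at larger amounts of compound and lower numbers for an effect already at smaller amounts), compound 1 gives 228 nM. Compound 2 `Cc1cc(OCCCCOc2ccc(C(=O)CC3CCCC3)c(O)c2C)ccc1C(=O)O` gives 564 nM in this assay, and compound 3 `Cc1c(OCCCCOc2ccc(C(=O)O)cc2F)ccc(C(=O)CC2CCCC2)c1O` gives 639 nM. Compound 3 therefore carries the highest of the three numbers, though the gap to compound 2 is small, with a 1.1-fold higher number from compound 2 to compound 3 (0.05 log units; within the scatter), while the gap to compound 1 is larger, with a 2.8-fold higher number from compound 1 to compound 3 (0.45 log units; beyond the scatter); the related step of a 2.5-fold higher number from compound 1 to compound 2 (0.39 log units; beyond the scatter) is of similar size.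

Compound 4 `Cc1ccc(C(=O)O)cc1OCCCCOc1ccc(C(=O)CC2CCCC2)c(O)c1C` is not yet measured. Its change from compound 3 is 5-carboxy-2-methylphenyl in place of 4-carboxy-2-fluorophenyl on an oxygen on a saturated carbon. Among the compounds with values here, the only step that bears directly on an exchange of one substituted carboxyphenyl for another is the one from compound 2 to compound 3, which stayed within the scatter. Within the data shown here, no step shows the 5-carboxy-2-methylphenyl group itself. On that basis no step beyond the scatter is expected in this assay for compound 4, in either direction. Compound 4 is thus estimated at 600 nM, with a range from 250 nM to 1500 nM, which would mean an expected step of a 1.1-fold lower number from compound 3 to compound 4 (0.03 log units; within the scatter).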

Compound 4, half-maximal effective concentration: 1290 nM
Compound 4: middle estimate off by 2.2-fold (0.33 log units), on the low side; low and high end bracket the measured number.
By their numbers in this assay, from the lowest: compound 1; then compounds 2 and 3 (each within the scatter of the next); then compound 4.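

In this assay, an exchange of one substituted carboxyphenyl group for another at this position now gives a step beyond the scatter, a 2.0-fold higher number from compound 3 to compound 4 (0.31 log units; beyond the scatter), whereas the earlier exchange of the 4-carboxy-3-methylphenyl group for the 4-carboxy-2-fluorophenyl group stayed within it. The 5-carboxy-2-methylphenyl group also separates from the 4-carboxy-3-methylphenyl group, with a 2.3-fold higher number from compound 2 to compound 4 (0.36 log units; beyond the scatter), so two methyl-bearing carboxyphenyl groups are not interchangeable here, and the 10 heavy atoms counted on both the leaving and the entering group show that the step from the fluorinated group comes without a change in that count. The largest step in the series is now a 5.7-fold higher number from compound 1 to compound 4 (0.75 log units; beyond the scatter), and compound 4 carries the highest number of the four, with its steps from all three others beyond the scatter.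

No evidence on the cause of these steps is available here. The compounds shown do not separate the place of the carboxylic acid from the exchange of fluorine for methyl, and they leave open how a 5-carboxy-2-fluorophenyl group, or a nitrile in place of the carboxylic acid, would read.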